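Benzimidazole series: methyl removal from compound 3

The source may report more compounds than this note shows. Statements on the series, on what has been measured and on what is new or still open speak of the compounds shown alone.

Measured so far:
- compound 1, `CCN(CC)Cc1cccc(Nc2nc3ccccc3n2Cc2ccc(F)cc2)c1O`: > 50000 nM
- compound 2, `CCN(CC)Cc1cc(F)cc(Nc2nc3ccccc3n2Cc2ccc(C(F)(F)F)cc2)c1O`: > 50000 nM
- compound 3, `CCN(CC)Cc1ccc(C)c(Nc2nc3ccccc3n2Cc2ccc(C(F)(F)F)cc2)c1O`: 33900 nM

All three compounds were read in an ADME assay on CHO cells (Cricetulus griseus) for inhibition, read by MTT assay; a lower number here means a stronger inhibitor, a higher number a weaker inhibitor. Compound 1 gives only a limit, > 50000 nM, not a number. Compound 2 likewise gives only a limit, > 50000 nM. Among the measured compounds shown here, compound 3 is the one compound of the three with a measured value, 33900 nM, and it stands close to the upper edge of what this assay reports; no step between measured compounds can be drawn, since no two of them differ in one place only. What the data do show is the limit of > 50000 nM in this assay, at which 2 of the 3 values shown sit.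

Compound 4, `CCN(CC)Cc1cccc(Nc2nc3ccccc3n2Cc2ccc(C(F)(F)F)cc2)c1O`, is not yet measured. Its change from compound 3 is hydrogen in place of methyl on an aromatic carbon: the methyl leaves and a hydrogen enters. Given that compound 3 itself sits at 33900 nM, only just inside the measurable range, the expectation for compound 4 is a step of about a 1.3-fold higher number from compound 3 to compound 4 (0.12 log units; within the scatter), toward weaker inhibition and most likely within the usual scatter. Compound 4 is therefore estimated at 45000 nM, with a range from 18000 nM to 110000 nM.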

Compound 4, half-maximal inhibitory concentration: > 50000 nM
Compound 4 was reported as a limit; the forecaster's own chance of this, stated with the estimate: 55%; at least 1.1-fold (0.04 log units) between middle value and limit.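

In this assay, among the compounds shown here, the change from methyl to hydrogen on this aromatic carbon, para to a (diethylamino)methyl group and meta to a hydroxy group, gives an at least 1.4-fold higher number from compound 3 to compound 4 (0.16 log units; that floor lies within the scatter) and this is the first step that can be read at all. It is a floor and not a size, so the data do not settle whether the methyl at this position matters: the true step may lie within the scatter or well beyond it. The steps to compound 4 from compound 1 and compound 2 cannot be read, since both ends of each are limits, and compound 3 remains the only compound with a measured number, the others sitting at a limit: the limit of > 50000 nM in this assay, at which 3 of the 4 values shown sit.

Open, from the compounds shown here alone, is whether another group on this carbon, such as chlorine, a methoxy group or an ethyl chain, would give a number further inside the measurable range of this assay than compound 3 does. Also open, going by these compounds, is whether a methyl here would read the same with fluoro in place of trifluoromethyl, the group carried by compound 1.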